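Swapping Chloro for Cyano on a Chromone Ether

A few compounds are considered here, and "the series" means these few. Any claim that something is new, unique, unknown or untested is made for them only; others in the source may bear on it.

Compound 1, `O=c1ccoc2ccc(OCCc3ccccc3)cc12`: in an assay on microsomes for inhibition of Amine oxidase [flavin-containing] B (Homo sapiens), read by fluorescence and spectrophotometry, with a stated time of 20 min (a higher number here means a weaker inhibitor, a lower number a stronger inhibitor), compound 1 gives 21 nM.
Compound 2, `O=c1ccoc2ccc(OCc3cccc(Cl)c3)cc12`: in this assay compound 2 gives 3.6 nM.

Within the data shown here, of the two numbers measured so far, compound 2 stands at the lower one, which here means the stronger inhibitor; compound 1 sits at the higher number, and the gap between them lies beyond the usual scatter of repeated measurements. Compound 3, `N#Cc1cccc(COc2ccc3occc(=O)c3c2)c1`, has not been measured yet. It differs from compound 2 in a single place: cyano in place of chloro on an aromatic carbon, in words, cyano in place of chloro on an aromatic carbon. Among the measured compounds shown here, no step between two measured compounds shows what such an exchange does, so there is no direct guide. The expectation is a modest step from compound 2, if any, near the edge of the scatter and more likely toward a somewhat higher number, estimated as a 2.2-fold higher number from compound 2 to compound 3 (0.35 log units; beyond the scatter). For compound 3 the estimated value in this assay is 8 nM, with a range from 2.5 nM to 30 nM.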

Compound 3, half-maximal inhibitory concentration: 76 nM
The estimate for compound 3 lay 9.5-fold (0.98 log units) below the measured number; the measured number lies above the stated range.
By their numbers in this assay, from the lowest: compound 2; then compound 1; then compound 3.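

The aromatic carbon carrying this group is far from indifferent to what sits on it: in this assay, cyano in place of chloro gives a 21-fold higher number from compound 2 to compound 3 (1.32 log units; beyond the scatter), a large step and well beyond the scatter. A single exchange on this ring, leaving the shared core and the linking chain of compound 2 untouched, is therefore enough to turn a strong inhibitor into a clearly weaker one. Nothing measured here explains why the nitrile, with its two heavy atoms and one hydrogen-bond acceptor, does so much worse than the single chlorine.

Among these compounds, with only two groups compared on this carbon, it remains open where a methyl, a methoxy group, a bromine or an amine would fall. Also open, on these data alone, is whether the same exchange on another carbon of this ring would produce a step of similar size.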